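The source may report more compounds than this note shows. Statements on the series, on what has been measured and on what is new or still open speak of the compounds shown alone.

Measured compounds in the series:

Compound 1 `O=C(CSc1nc(Nc2ccccc2)c2ccccc2n1)Nc1ccccc1Cl` — in a functional assay on MDA-MB-231 cells (Homo sapiens) for inhibition, read by MTT assay, with a stated time of 72 h (on this read-out lower numbers stand for stronger inhibition and higher numbers for weaker inhibition), compound 1 gives 24400 nM.
Compound 2 `O=C(CSc1nc(Nc2ccccc2)c2ccccc2n1)Nc1ccccc1Br` — compound 2 gives 14100 nM.
Compound 3 `CCc1cccc(NC(=O)CSc2nc(Nc3ccccc3)c3ccccc3n2)c1` — compound 3 gives 12400 nM.

Compound 3 has the lowest number of the three, but the steps of a 2.0-fold lower number from compound 1 to compound 3 (0.29 log units; within the scatter) and a 1.1-fold lower number from compound 2 to compound 3 (0.06 log units; within the scatter) are both within the scatter, as is a 1.7-fold lower number from compound 1 to compound 2 (0.24 log units; within the scatter), so no ordering among the three can be claimed.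

Compound 4 `C=CC(=O)Nc1cccc(NC(=O)CSc2nc(Nc3ccccc3)c3ccccc3n2)c1` has not yet been measured. The change is (vinylcarbonyl)amino in place of ethyl on an aromatic carbon. Within the data shown here, none of the measured steps touches this position or this kind of group: the steps so far exchange halogens on the amide-side ring or move from a halogenated to an ethyl-bearing ring, and all stay within the scatter. Among the measured compounds shown here, they give no basis for expecting a step beyond the scatter in this assay in either direction, and the new group has no precedent. Compound 4 is therefore estimated at 10000 nM, with a range from 3000 nM to 35000 nM, which is a step of a 1.2-fold lower number from compound 3 to compound 4 (0.09 log units; within the scatter) and is expected to be within the scatter.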

Compound 4, half-maximal inhibitory concentration: 10200 nM
Compound 4: middle estimate off by 1.0-fold (0.01 log units), on the low side, and the stated range covers the measured number.
By their numbers in this assay, from the lowest: compounds 4, 3, 2 and 1 (each within the scatter of the next, the first and the last beyond it).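

In this assay, the exchange of ethyl for the larger (vinylcarbonyl)amino group, which brings a hydrogen-bond donor and a hydrogen-bond acceptor, gives a 1.2-fold lower number from compound 3 to compound 4 (0.08 log units; within the scatter), so this substitution on the aromatic carbon leaves the number unresolved from that of the ethyl compound. Among these compounds, the comparison with the 2-bromophenyl amide gives a 1.4-fold lower number from compound 2 to compound 4 (0.14 log units; within the scatter), while that with the 2-chlorophenyl amide gives a 2.4-fold lower number from compound 1 to compound 4 (0.38 log units; beyond the scatter), the only modest separation and the first step to pass the scatter. No supporting data bear on what lies behind these steps.

Still open, on these data alone, is whether propanoylamino, with the vinyl double bond saturated, would give a number close to that of compound 4. An amine or a carboxylic acid on the same aromatic carbon could test how far this tolerance extends.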